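A few compounds are considered here, and "the series" means these few. Any claim that something is new, unique, unknown or untested is made for them only; others in the source may bear on it.

Measured compounds:
compound 1, `Cc1cccc(Cc2nc3cc(O[C@H]4CC[C@@H](C(=O)O)CC4)ccc3o2)c1`, 140 nM
compound 2, `Cc1cccc(Cc2nc3cc(O[C@H]4CC[C@@H](C(=O)O)CC4)ccc3n2C)c1`, 30 nM

The two compounds share a core and differ only at the ring nitrogen of that core. In an assay on isolated protein for inhibition of Long-chain-fatty-acid--CoA ligase 1 (Mus musculus), read by mass spectrometry, with a stated time of 90 min, in the presence of a further agent that is not named here (a lower number here means a stronger inhibitor, a higher number a weaker inhibitor), compound 1 gives 140 nM, and compound 2 gives 30 nM, so compound 2 stands as the lower of the two numbers, and its gap to compound 1 lies beyond the scatter.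

Compound 3, `Cc1cccc(Oc2nc3cc(O[C@H]4CC[C@@H](C(=O)O)CC4)ccc3n2C)c1`, has not yet been measured. It differs from compound 2 in one place: 3-methylphenoxy in place of 3-methylbenzyl on an aromatic carbon. Going by the values given here, no measured pair in this set shows a swap of this kind, so the size of the step cannot be read from the data. The expectation is a small change, if any, in either direction, and the step of a 1.7-fold higher number from compound 2 to compound 3 (0.22 log units; within the scatter) is estimated to stay close to the scatter. On that basis compound 3 is expected to give 50 nM, within a range of 15 nM to 200 nM.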

Compound 3, half-maximal inhibitory concentration: 21000 nM
Beside the measured number, compound 3's estimate is 420-fold (2.62 log units) below it, outside the stated range (above it).
By their numbers in this assay, from the lowest: compound 2; then compound 1; then compound 3.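

In this assay, exchanging 3-methylbenzyl for 3-methylphenoxy on the aromatic carbon between two ring nitrogen atoms gives a 700-fold higher number from compound 2 to compound 3 (2.85 log units; beyond the scatter). Both groups have the same number of heavy atoms and the same carbon ring, and the count differs by one oxygen in place of one carbon and one hydrogen-bond acceptor, so this position is highly sensitive to a minimal change in the group it carries. The earlier compounds shown here showed only a change at the ring nitrogen of the core and gave no view of this position. Nothing available here accounts for the size of this step.

The compounds shown leave open whether an amine or a sulfur atom as the link to the 3-methylphenyl ring would fare like the carbon or the oxygen. They also leave open whether 3-methylphenoxy would have the same effect on the core of compound 1.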